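A Second Methoxy Group and the Expected Effect on Cell Growth

The source may report more compounds than this note shows. Statements on the series, on what has been measured and on what is new or still open speak of the compounds shown alone.

Measured compounds:
Compound 1, `COc1ccc(-c2cc(/C=C/C(=O)c3ccc(N)cc3)[nH]n2)cc1`: -6%
Compound 2, `COc1cc(-c2cc(/C=C/C(=O)c3ccc(Cl)c(Cl)c3)[nH]n2)cc(OC)c1OC`: 52%

Both compounds were tested in a functional assay on OVCAR-4 cells (Homo sapiens) for cytotoxicity, read by sulforhodamine B assay, with a stated time of 48 h, tested at 10 uM; on this read-out higher numbers stand for a weaker effect at the one concentration tested and lower numbers for a stronger effect. Of the two numbers, compound 1 has the lowest, meaning the stronger effect at the single concentration tested, while compound 2 sits well above it, a gap that lies beyond the usual scatter of repeated measurements. The two compounds differ in several places at once, so their values show only where each stands and not what any single change does.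

Compound 3, `COc1ccc(-c2cc(/C=C/C(=O)c3ccc(N)cc3)[nH]n2)cc1OC`, has not yet been measured. It differs from compound 1 in one place: methoxy in place of hydrogen on an aromatic carbon. Among the compounds with values here, no pair of measured compounds differs by this kind of change, so the size of its effect cannot be read from what has been measured. For the step from compound 1 to compound 3, a change of none beyond the scatter is expected, in either direction, which gives a number 11 percentage points higher from compound 1 to compound 3 (beyond the scatter). On that basis compound 3 is estimated to give about 5%, within a range from -25% to 35%.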

Compound 3, a percentage reported as activity, at one concentration (the size of the read-out at that concentration, not a potency): 24%
For compound 3 the middle estimate is 19 percentage points below the measured one, within the range that was stated.
By their numbers in this assay, from the lowest: compound 1; then compound 3; then compound 2.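

Methoxy in place of hydrogen on an aromatic carbon, ortho to a methoxy group and meta to a large group, gives a number 30 percentage points higher from compound 1 to compound 3 (beyond the scatter) in this assay. At this position, then, adding a methoxy group to the core of compound 1 weakens the effect seen at the one concentration tested, and the size of that loss lies beyond what repeated measurements would usually scatter. The earlier compounds could not show this, since they differ in several places at once, while this pair isolates a single change; the data shown offer no measurement that bears on why the step occurs.

From the compounds shown here alone, what stays open is whether the step belongs to methoxy itself or would also appear with another group at the same position, such as a hydroxyl group, a fluorine atom, an amine or the longer ethoxy chain. Within the data shown here, it is also open whether the same change would give a step of similar size when the amino group of compound 1 is replaced by other groups, as the single pair here speaks only for this one background.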